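A few compounds are considered here, and "the series" means these few. Any claim that something is new, unique, unknown or untested is made for them only; others in the source may bear on it.

Measured compounds:
Compound 1, `Cc1cc(C)nc(SCc2cc(=O)c3cc(Cl)ccc3o2)n1`: > 25000 nM
Compound 2, `Cc1cc(C)nc(SCc2cc(=O)c3ccccc3o2)n1`: > 25000 nM
Compound 3, `Nc1nnc(SCc2cc(=O)c3ccccc3o2)s1`: > 25000 nM

Three compounds of the series have been run in a functional assay on SW480 cells (Homo sapiens) for cytotoxicity, read by MTT assay, with a stated time of 72 h; a higher number here means a weaker inhibitor, a lower number a stronger inhibitor. In this assay compound 1 gives only a limit, > 25000 nM. Compound 2 likewise gives only a limit in this assay, > 25000 nM. For compound 3 the readout in this assay is again a limit, > 25000 nM. All three values rest on (the limit of > 25000 nM in this assay, at which 3 of the 3 values shown sit), so no ordering among compound 1, compound 2 and compound 3 can be read from them.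

Among the measured compounds shown here, the one change that is repeated is chloro in place of hydrogen on an aromatic carbon. The step it makes between the measured pair is a step that the two limits leave unreadable from compound 2 to compound 1, since both ends are limits. The unmeasured compound 4, `Nc1nnc(SCc2cc(=O)c3cc(Cl)ccc3o2)s1`, carries the same change on the core of compound 3: chloro in place of hydrogen on an aromatic carbon. The place lines of the two changes are the same word for word, so it is the same change. The difference between the core of compound 2 and the core of compound 3 is not broken down here.

For the measured compounds named here, because of the limit of > 25000 nM in this assay, at which 3 of the 3 values shown sit, and the unreadable size of a step that the two limits leave unreadable from compound 2 to compound 1, there is no measured step on which to build a numerical expectation for compound 4; the expectation can only follow the three limits. The step from compound 3 to compound 4 in this assay is therefore expected to be a step that the limit leaves unreadable from compound 3 to compound 4, meaning little change. Compound 4 is expected to give 30000 nM in this assay, most probably reported as a limit, with a range from 15000 nM to 100000 nM.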

Compound 4, half-maximal inhibitory concentration: > 25000 nM
Compound 4: no number, only a limit (the forecaster's own chance of this, stated with the estimate: 85%); the middle value lies beyond the limit too.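

In this assay compound 4 gives > 25000 nM, which is a limit and not a number. No step can be read from compound 3 to compound 4, as both ends are limits: the limit of > 25000 nM in this assay, at which 4 of the 4 values shown sit.

The compounds shown leave open what size, if any, the step for chloro in place of hydrogen on an aromatic carbon has on either core, and how the two cores compare in this assay.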